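The source may hold more compounds than are shown below. What is called first, only, known or untested is meant among the compounds shown, and "the series" means these compounds.

Compound 1 `CN(C)CCn1cnnc1-c1cc(Oc2ccc(NC(=O)N/N=C/c3ccc(Cl)cc3Cl)cc2F)ccn1` gives 810 nM in a functional assay on A549 cells (Homo sapiens) for cytotoxicity, read by MTT assay, with a stated time of 72 h; a higher number here means a weaker inhibitor, a lower number a stronger inhibitor; compound 2 `COc1ccc(OC)c(/C=N/NC(=O)Nc2ccc(Oc3ccnc(-c4nncn4CCN(C)C)c3)c(F)c2)c1` gives 1950 nM; compound 3 `CN(C)CCn1cnnc1-c1cc(Oc2ccc(NC(=O)N/N=C/c3cccc(Br)c3)cc2F)ccn1` gives 970 nM.

In this assay compound 3 holds the second highest of the three numbers. The nearest is compound 1, with a 1.2-fold higher number from compound 1 to compound 3 (0.08 log units; within the scatter); the furthest is compound 2, with a 2.0-fold lower number from compound 2 to compound 3 (0.30 log units; within the scatter). Compound 4 `CN(C)CCn1cnnc1-c1cc(Oc2ccc(NC(=O)N/N=C/c3ccc(O)cc3)cc2F)ccn1` differs from compound 3 only by 4-hydroxyphenyl in place of 3-bromophenyl on a carbon with a double bond to nitrogen. The measured steps that bear on this are the swaps of the aryl group on the same carbon: a 2.4-fold higher number from compound 1 to compound 2 (0.38 log units; beyond the scatter), a 1.2-fold higher number from compound 1 to compound 3 (0.08 log units; within the scatter) and a 2.0-fold lower number from compound 2 to compound 3 (0.30 log units; within the scatter), all of them small. Compound 4 is therefore expected to show a 1.5-fold higher number from compound 3 to compound 4 (0.19 log units; within the scatter), a step scarcely beyond the scatter. The estimate for compound 4 is 1500 nM, with a range from 600 nM to 4000 nM.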

Compound 4, half-maximal inhibitory concentration: 3560 nM
Compound 4: the middle estimate sits 2.4-fold (0.38 log units) below what was measured; measured number inside the range.
By their numbers in this assay, from the lowest: compounds 1, 3, 2 and 4 (each within the scatter of the next, the first and the last beyond it).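

In this assay, among the compounds shown here, 4-hydroxyphenyl is the first group on this carbon to stand clearly apart from both the 3-bromophenyl and 2,4-dichlorophenyl groups: a 3.7-fold higher number from compound 3 to compound 4 (0.56 log units; beyond the scatter) and a 4.4-fold higher number from compound 1 to compound 4 (0.64 log units; beyond the scatter) are both beyond the scatter. Yet a 1.8-fold higher number from compound 2 to compound 4 (0.26 log units; within the scatter) stays within it, so this change does not separate compound 4 from the 2,5-dimethoxyphenyl compound. No evidence here explains these steps. The compounds shown leave open whether the hydroxyl itself matters or only the loss of the halogens, which a 4-methoxyphenyl or 4-aminophenyl group on this carbon could help to separate.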